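Notes on two measured compounds and one isomer

This account rests on a few compounds, and the source may have more. Where it says the series, first, only, none or still open, it means among the compounds named here.

Among the compounds with values here, compound 1 `CCOc1ccc2nc(Cl)c(/C=N/NC(=O)c3cc4ccc(O)cc4oc3=O)cc2c1` and compound 2 `O=C(N/N=C/c1ccncc1)c1cc2ccccc2oc1=O` are the two compounds measured so far in a functional assay on HepG2 cells (Homo sapiens) for antiproliferative activity, read by fluorescence and resazurin assay, with a stated time of 48 h; on this read-out lower numbers stand for stronger inhibition and higher numbers for weaker inhibition. In this assay compound 1 gives 19200 nM. In this assay compound 2 gives 17200 nM. Compound 2 holds the lower of the two numbers shown, but its gap to compound 1 lies within the usual scatter, so the two stand level and neither can be called the more potent. Within the data shown here, no pair of measured compounds differs in a single place, so no measured step is available to lean on.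

Compound 3 `O=C(N/N=C/c1cccnc1)c1cc2ccccc2oc1=O` is not yet measured. It differs from compound 2 in one place: pyridin-3-yl in place of pyridin-4-yl on a carbon with a double bond to nitrogen. Both compounds hold the same atoms, joined differently. Among the measured compounds shown here, with no measured step for a change of this kind, the expectation for the step is no size beyond the scatter, in neither direction. Compound 3 is expected to give about 17000 nM in this assay, within a range from 8000 nM to 40000 nM. This estimate means a step of a 1.0-fold lower number from compound 2 to compound 3 (0.01 log units; within the scatter), which is expected to stay within the scatter.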

Compound 3, half-maximal inhibitory concentration: 15900 nM
The estimate for compound 3 lay 1.1-fold (0.03 log units) above the measured number; measured number inside the range.
By their numbers in this assay, from the lowest: compounds 3, 2 and 1 (each within the scatter of the next).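

In this assay, within the data shown here, pyridin-3-yl in place of pyridin-4-yl on a carbon with a double bond to nitrogen gives a 1.1-fold lower number from compound 2 to compound 3 (0.03 log units; within the scatter) and supplies the first measured single-place step. At this position the two pyridine isomers, alike in heavy atoms and in counted hydrogen-bond donors and acceptors, stand level, so this read-out does not tell one attachment of the ring from the other. The step therefore sets no preference between pyridin-3-yl and pyridin-4-yl here, and no measurement shown speaks to what lies behind this level reading.

The compounds shown leave open whether the level reading holds only for these two isomers or extends to other groups at this carbon, such as pyridin-2-yl, an unsubstituted phenyl ring, or a phenyl ring carrying an amine or a carboxylic acid. Among these compounds, compound 1 differs from compound 2 and compound 3 in more than one place, so it offers no step for this position, and the contribution of each of its separate features to the number in this assay also remains open.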